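Lengthening a fluorinated amide chain by one carbon

The source may report more compounds than this note shows. Statements on the series, on what has been measured and on what is new or still open speak of the compounds shown alone.

Compound 2 `COc1cc(C(=O)NS(=O)(=O)c2ccccc2C)ccc1Cc1cn(C)c2ccc(C(=O)NCC(C)C(F)(F)F)cc12` gives 5.89 in a physicochemical assay for lipophilicity; a higher number here means a more lipophilic compound, a lower number a more polar compound. Compound 1 `CCC(C)CNC(=O)c1ccc2c(c1)c(Cc1ccc(C(=O)NS(=O)(=O)c3ccccc3C)cc1OC)cn2C` gives 5.85, and the step of a number 0.04 log units higher from compound 1 to compound 2 (within the scatter) leaves the two within the scatter of each other. Compound 3 `COc1cc(C(=O)NS(=O)(=O)c2ccccc2C)ccc1Cc1cn(C)c2ccc(C(=O)NCCC(C)C(F)(F)F)cc12` carries 2-(trifluoromethyl)propyl in place of 1-(trifluoromethyl)ethyl on a saturated chain carbon bound to an amide-type nitrogen. Among the compounds with values here, none of the measured steps matches this change: the step from compound 1 to compound 2 exchanged one group for another of similar size rather than adding a chain carbon. With no direct guide, a small rise is expected, with the step of a number 0.31 log units higher from compound 2 to compound 3 (beyond the scatter). Compound 3 is estimated at 6.2 in this assay, with a range from 5.8 to 6.6.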

Compound 3, partition coefficient: 6.3
Compound 3: the middle estimate sits 0.10 log units below what was measured; measured number inside the range.
By their numbers in this assay, from the lowest: compounds 1 and 2 (each within the scatter of the next); then compound 3.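

In this assay, within the data shown here, one more chain carbon at this place, 2-(trifluoromethyl)propyl in place of 1-(trifluoromethyl)ethyl, gives a number 0.41 log units higher from compound 2 to compound 3 (beyond the scatter), the first step here to pass the scatter. Measured against the sec-butyl chain, the change gives a number 0.45 log units higher from compound 1 to compound 3 (beyond the scatter), whereas the exchange of ethyl for trifluoromethyl left compound 1 and compound 2 within the scatter of each other. Nothing measured here accounts for these steps. Still open, from the compounds shown here alone, is whether 3-(trifluoromethyl)butyl would move the number further. Also open, going by these compounds, is what a chain ending in an amine or a carboxylic acid would give at this place.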